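The compounds below may be only part of what the source reports. "The series", "measured", "known", "first", "only" and "open" are said of these compounds alone.

Two compounds with the shared catechol-nitro core have been examined in an assay on isolated protein for inhibition of Amine oxidase [flavin-containing] B (Homo sapiens), read by fluorescence; a lower number here means a stronger inhibitor, a higher number a weaker inhibitor. Compound 1 `N#Cc1ccc(/C=C/C(=O)c2cc(O)c(O)c([N+](=O)[O-])c2)cc1` gives 56600 nM. Compound 2 `CC(=O)N1N=C(c2cc(O)c(O)c([N+](=O)[O-])c2)CC1c1nccs1` gives 68200 nM, a number that sits within the usual scatter of the value of compound 1, so no order can be read between the two. Compound 3 `CC(=O)N1N=C(c2cc(O)c(O)c([N+](=O)[O-])c2)CC1c1ccoc1` carries furan-3-yl in place of 1,3-thiazol-2-yl on a saturated ring carbon. Among the compounds with values here, no step between two measured compounds exists to show how such a swap moves the number, so compound 3 is expected to stay close to compound 2, with a step of a 1.0-fold higher number from compound 2 to compound 3 (0.01 log units; within the scatter) that need not exceed the scatter. Compound 3 is estimated at 70000 nM, within 25000 nM to 200000 nM.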

Compound 3, half-maximal inhibitory concentration: 126000 nM
Beside the measured number, compound 3's estimate is 1.8-fold (0.26 log units) below it, and the stated range covers the measured number.
By their numbers in this assay, from the lowest: compounds 1, 2 and 3 (each within the scatter of the next, the first and the last beyond it).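

In this assay, within the data shown here, the exchange of 1,3-thiazol-2-yl for furan-3-yl on a saturated ring carbon gives the only step at this position (a 1.8-fold higher number from compound 2 to compound 3 (0.27 log units; within the scatter)). This replacement of one five-membered aromatic ring by another, with one ring hetero atom in place of two, is thus not shown to move the number beyond the scatter. No measurement at hand bears on the reason for this step. The compounds shown leave open how an amine, a carboxylic acid or a longer chain on this ring carbon would read in this assay.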